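Benzyl on the aromatic nitrogen: expecting no shift

The compounds below may be only part of what the source reports. "The series", "measured", "known", "first", "only" and "open" are said of these compounds alone.

Measured in a functional assay on A549 cells (Homo sapiens) for cytotoxicity, read by MTT assay, with a stated time of 72 h; a higher number here means a weaker inhibitor, a lower number a stronger inhibitor:
- compound 1 `CC1CCN(Cc2ccc3nc(NC(=O)N/N=C/c4cn(Cc5ccc(Cl)cc5Cl)c5ccccc45)sc3c2)CC1`: 3640 nM
- compound 2 `CN(C)Cc1ccc2nc(NC(=O)N/N=C/c3cn(Cc4ccc(C(C)(C)C)cc4)c4ccccc34)sc2c1`: 1850 nM
- compound 3 `CC1CCN(Cc2ccc3nc(NC(=O)N/N=C/c4c[nH]c5ccccc45)sc3c2)CC1`: 3580 nM

The three values are not separated: compound 3, at 3580 nM, lies within the scatter of both other compounds in this assay. Compound 4 `Cc1ccc(Cn2cc(/C=N/NC(=O)Nc3nc4ccc(CN5CCC(C)CC5)cc4s3)c3ccccc32)cc1` has 4-methylbenzyl in place of hydrogen on an aromatic nitrogen, relative to compound 3: 4-methylbenzyl in place of hydrogen on an aromatic nitrogen.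

For the measured compounds named here, one measured step bears directly on this nitrogen. Going a 1.0-fold lower number from compound 1 to compound 3 (0.01 log units; within the scatter), the change stays within the scatter, so a substituted benzyl group there made no measurable difference in that pair. Going by the values given here, compound 2 carries a different benzyl group but also differs elsewhere, so it gives no clean step, though its value of 1850 nM stays in the same range. This rests on a single pair, and no group of the same kind as 4-methylbenzyl has been measured on this scaffold.

No change beyond the scatter is therefore expected in this assay, and the expected step is a 1.2-fold lower number from compound 3 to compound 4 (0.08 log units; within the scatter). The estimate for compound 4 is 3000 nM, with an expected range of 1400 nM to 6500 nM.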

Compound 4, half-maximal inhibitory concentration: 2180 nM
Estimate against measurement, compound 4: 1.4-fold (0.14 log units) above, within the range that was stated.
By their numbers in this assay, from the lowest: compounds 2, 4, 3 and 1 (each within the scatter of the next).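

In this assay, the step with 4-methylbenzyl on the aromatic nitrogen is a 1.6-fold lower number from compound 3 to compound 4 (0.22 log units; within the scatter) and so gives a second matched pair at this nitrogen, now with a benzyl group free of chlorine, that stays within the scatter. Exchanging the aryl part of the benzyl group gives a 1.7-fold lower number from compound 1 to compound 4 (0.22 log units; within the scatter) and does not separate 4-methylphenyl from 2,4-dichlorophenyl, so hydrogen and both benzyl groups are indistinguishable here on the same remainder of the molecule. No measurement at hand accounts for how small these steps are.

Still open, going by these compounds, is whether a group of another kind on this nitrogen, such as a carboxylic acid or an amine on a longer chain, would move the number beyond the scatter. On these data alone, it is also open whether the same holds with the other amine of compound 2, which has no matched partner at this nitrogen.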